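Methoxy for Tert-Butyl: A Step Between Two Limits

The compounds below may be only part of what the source reports. "The series", "measured", "known", "first", "only" and "open" are said of these compounds alone.

Compound 1 `CC(C)(C)c1ccc(S(=O)(=O)n2cc(/C=C/C(=O)c3ccncc3)c3ccccc32)cc1` stands at the limit of an ADME assay on HEK293 cells (Homo sapiens) for antiproliferative activity, read by MTT assay, with a stated time of 48 h; a lower number here means a stronger inhibitor, a higher number a weaker inhibitor: in this assay compound 1 gives > 150000 nM, a limit rather than a number. Compound 2 `O=C(/C=C/c1cn(S(=O)(=O)c2ccc([N+](=O)[O-])cc2)c2ccccc12)c1ccncc1` also gives > 150000 nM in this assay, again a limit. The step that the two limits leave unreadable from compound 1 to compound 2 is therefore unreadable, as the limit of > 150000 nM in this assay, at which 2 of the 2 values shown sit, records. Compound 3 `COc1ccc(S(=O)(=O)n2cc(/C=C/C(=O)c3ccncc3)c3ccccc32)cc1` differs from compound 1 by methoxy in place of tert-butyl on an aromatic carbon. Among the compounds with values here, no measured step reads a size for this kind of change, so no step beyond the scatter is expected, and compound 3 is expected near 200000 nM, between 80000 nM and 600000 nM, most likely again as a limit. The expected step that the limit leaves unreadable from compound 1 to compound 3 is small.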

Compound 3, half-maximal inhibitory concentration: > 150000 nM
Compound 3 gave a limit, no number (the forecaster's own chance of this, stated with the estimate: 80%); the middle value is on the limit's open side.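

No step among compound 1, compound 2 and compound 3 can be read in this assay, because all three stand at the same limit: the limit of > 150000 nM in this assay, at which 3 of the 3 values shown sit.

The compounds shown leave open whether any group at this place on the shared core would give a number rather than a limit in this assay.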